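The source may hold more compounds than are shown below. What is called first, only, known or untested is meant among the compounds shown, and "the series" means these compounds.

In a functional assay on NCI-H1299 cells (Homo sapiens) for antiproliferative activity, read by XTT assay, with a stated time of 72 h (on this read-out higher numbers stand for weaker inhibition and lower numbers for stronger inhibition), three close relatives of one shared core have been measured. Compound 1 `COc1ccc(-c2cc3ccccc3nc2/C=C/C(=O)c2ccc(F)cc2)cc1` gives 820 nM. Compound 2 `COc1ccc(-c2cc3ccccc3nc2/C=C/C(=O)c2ccc(OC)c(OC)c2)cc1` gives 1050 nM, and the step of a 1.3-fold higher number from compound 1 to compound 2 (0.11 log units; within the scatter) is one that no weight should be put on. Compound 3 `COc1ccc(-c2cc3ccccc3nc2/C=C/C(=O)c2ccc(N)cc2)cc1` gives 6510 nM, the highest of the three numbers; the steps of a 7.9-fold higher number from compound 1 to compound 3 (0.90 log units; beyond the scatter) and a 6.2-fold higher number from compound 2 to compound 3 (0.79 log units; beyond the scatter) both mark compound 3 as the weakest inhibitor among them.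

Compound 4 `COc1ccc(-c2cc3ccccc3nc2/C=C/C(=O)c2ccc(Br)s2)cc1` has not yet been measured. The change from compound 3 is 5-bromothiophen-2-yl in place of 4-aminophenyl on a carbonyl carbon. Going by the values given here, the steps that bear on it are the two that arrive at compound 3, where bringing in the amino-bearing ring went with a modest rise in the number. The change to compound 4 removes that ring again and brings in a halogen-bearing ring, as in compound 1, so a fall in this assay of roughly the same size is expected, back towards the level of compound 1. The expected step is a 7.2-fold lower number from compound 3 to compound 4 (0.86 log units; beyond the scatter). Compound 4 is therefore estimated at 900 nM, within a range from 300 nM to 3000 nM.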

Compound 4, half-maximal inhibitory concentration: 710 nM
Compound 4: middle estimate off by 1.3-fold (0.10 log units), on the high side, and the stated range covers the measured number.
By their numbers in this assay, from the lowest: compounds 4, 1 and 2 (each within the scatter of the next); then compound 3.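

In this assay the carbonyl carbon now carries a five-membered aromatic ring with one hetero atom, not only six-membered rings of carbon. a 9.2-fold lower number from compound 3 to compound 4 (0.96 log units; beyond the scatter) sets 5-bromothiophen-2-yl clearly apart from 4-aminophenyl, while a 1.2-fold lower number from compound 1 to compound 4 (0.06 log units; within the scatter) and a 1.5-fold lower number from compound 2 to compound 4 (0.17 log units; within the scatter) show no real difference from the 4-fluorophenyl and 3,4-dimethoxyphenyl rings. A six-membered ring of carbon is therefore not needed at this position for the number to stay at this level, and among these four compounds only the amino-bearing compound 3 stands apart.

The compounds shown leave open what the bromine itself contributes, which a thiophen-2-yl ring without bromine or a 5-chlorothiophen-2-yl ring would test. No measurement here explains why the amino-bearing ring stands apart.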